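Removing a Methyl from the Anilide of Compound 1

The source may report more compounds than this note shows. Statements on the series, on what has been measured and on what is new or still open speak of the compounds shown alone.

Compound 1 `Cc1ccccc1NC(=O)/C=C/c1coc2cc(O)ccc2c1=O` gives 11100 nM in a functional assay on Huh-7 cells (Homo sapiens) for inhibition, read by MTT assay, with a stated time of 48 h; on this read-out higher numbers stand for weaker inhibition and lower numbers for stronger inhibition. Among the three measured compounds, compound 1 has the lowest number, although compound 2 `COc1ccc2c(=O)c(/C=C/C(=O)NCc3ccccc3)coc2c1` with 13600 nM and compound 3 `COc1ccc2c(=O)c(/C=C/C(=O)NCc3ccc(C)cc3)coc2c1` with 14300 nM both lie within the scatter of it. Compound 4 `O=C(/C=C/c1coc2cc(O)ccc2c1=O)Nc1ccccc1` differs from compound 1 by hydrogen in place of methyl on an aromatic carbon. Going by the values given here, the only measured step involving a methyl on an aromatic carbon is a 1.1-fold higher number from compound 2 to compound 3 (0.02 log units; within the scatter), where the methyl sits on a different ring, and that step stayed within the scatter. Among the compounds with values here, no step at the same place is known. Compound 4 is therefore expected to give a number close to that of compound 1, with an estimated step of a 1.0-fold higher number from compound 1 to compound 4 (0.02 log units; within the scatter). The estimate for compound 4 is 11500 nM, ranging from 6000 nM to 23000 nM.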

Compound 4, half-maximal inhibitory concentration: 3880 nM
Compound 4: middle estimate off by 3.0-fold (0.47 log units), on the high side; measured number below the stated range.
By their numbers in this assay, from the lowest: compound 4; then compounds 1, 2 and 3 (each within the scatter of the next).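

Going by these compounds alone, a methyl on this aromatic carbon, ortho to a large group, is not a silent change: going from 2-methylphenyl to phenyl gives a 2.9-fold lower number from compound 1 to compound 4 (0.46 log units; beyond the scatter) in this assay, the only step so far that lies beyond the scatter. A methyl on an aromatic carbon therefore does not count the same on every core: the same change on two cores in this assay, a 1.1-fold higher number (0.02 log units; within the scatter) from compound 2 to compound 3 and a 2.9-fold higher number (0.46 log units; beyond the scatter) from compound 4 to compound 1, 2.7-fold (0.43 log units) apart, beyond the scatter of two such steps.

Still open, as far as these compounds go, is whether another group at this place, such as a methoxy, a chlorine or an ethyl, would give a number nearer compound 1 or compound 4.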